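Anilide substituent changes on the shared core

The compounds below may be only part of what the source reports. "The series", "measured", "known", "first", "only" and "open" are said of these compounds alone.

Measured compounds:
compound 1 `Nc1ccc(NC(=O)c2cn(Cc3c(F)cccc3F)c3ccc(=O)[nH]c3c2=O)cc1` — 104 nM
compound 2 `O=C(Nc1ccccc1)c1cn(Cc2c(F)cccc2F)c2ccc(=O)[nH]c2c1=O` — 94 nM
compound 3 `CNC(=O)c1ccc(NC(=O)c2cn(Cc3c(F)cccc3F)c3ccc(=O)[nH]c3c2=O)cc1` — 29 nM

In an in vitro assay on Sf21 cells for inhibition of high affinity 3',5'-cyclic-AMP phosphodiesterase 7A (Homo sapiens), read by scintillation proximity assay, with a stated time of 30 min (on this read-out higher numbers stand for weaker inhibition and lower numbers for stronger inhibition), compound 1 gives 104 nM, the highest of the three numbers. Its nearest neighbour is compound 2, with the step of a 1.1-fold lower number from compound 1 to compound 2 (0.04 log units; within the scatter), so the amino group and hydrogen at this place read the same. The furthest is compound 3, with a 3.6-fold lower number from compound 1 to compound 3 (0.55 log units; beyond the scatter); the matching step a 3.2-fold lower number from compound 2 to compound 3 (0.51 log units; beyond the scatter) shows the same modest gain for a methylcarbamoyl group at that place.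

Compound 4 `CS(=O)(=O)c1ccc(NC(=O)c2cn(Cc3c(F)cccc3F)c3ccc(=O)[nH]c3c2=O)cc1` differs from compound 1 by methylsulfonyl in place of amino on an aromatic carbon. The two steps that bear on it point in different directions: removing the amino group changed nothing, while putting an acceptor-bearing group para to the large group lowered the number modestly. Methylsulfonyl brings acceptors and no donor to the same place, so a modest lowering in this assay is expected, though smaller than for compound 3 is equally plausible. Compound 4 is therefore expected to give 50 nM, within 20 nM to 150 nM. This estimate corresponds to the expected step of a 2.1-fold lower number from compound 1 to compound 4 (0.32 log units; beyond the scatter).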

Compound 4, half-maximal inhibitory concentration: 27 nM
Compound 4: the middle estimate sits 1.9-fold (0.27 log units) above what was measured; the range from low to high includes it.
By their numbers in this assay, from the lowest: compounds 4 and 3 (each within the scatter of the next); then compounds 2 and 1 (each within the scatter of the next).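

In this assay methylsulfonyl on this aromatic carbon, para to a large group, gives a gain beyond the scatter against both earlier reference points: a 3.9-fold lower number from compound 1 to compound 4 (0.59 log units; beyond the scatter) and a 3.5-fold lower number from compound 2 to compound 4 (0.54 log units; beyond the scatter) are steps of similar size. The step of a 1.1-fold lower number from compound 3 to compound 4 (0.03 log units; within the scatter) places methylsulfonyl level with methylcarbamoyl, so the gain is not unique to methylcarbamoyl and, with 0 hydrogen-bond donors on methylsulfonyl, does not require a donor on the entering group. No supporting data on hand speak to why these two groups read alike.

From the compounds shown here alone, it remains open whether a carboxylic acid, a nitrile or a sulfonamide at this place would read with compound 3 and compound 4 or with compound 1 and compound 2. Also open, going by these compounds, is whether a longer chain on the sulfonyl would keep the gain.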